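This account rests on a few compounds, and the source may have more. Where it says the series, first, only, none or still open, it means among the compounds named here.

Series notes, hydrazone set. The point of reference is compound 1 `C/C(=N\NC(=O)c1cccnc1)c1ccccc1O`, which in a toxicity assay (H9c2 cells) for cytotoxicity, with Rattus norvegicus as the target, read by neutral red uptake, with a stated time of 72 h (a lower number here means a stronger inhibitor, a higher number a weaker inhibitor), gives 6800 nM. Compound 2 `CC/C(=N\NC(=O)c1cnccn1)c1ccccc1O` carries an ethyl in place of the methyl and a pyrazin-2-yl on the carbonyl carbon. In this assay compound 2 returns only a limit, > 100000 nM. Compound 3 `CC/C(=N\NC(=O)c1ccnnc1)c1ccccc1O` keeps the ethyl and carries a pyridazin-4-yl on the carbonyl carbon. In this assay compound 3 likewise returns only a limit, > 200000 nM. Compound 3 therefore stands at one of two limits in the set; the limit of > 100000 nM in this assay, at which 1 of the 3 values shown sits, and the limit of > 200000 nM in this assay, at which 1 of the 3 values shown sits, are the two, and no number is available for either compound. The step that the two limits leave unreadable from compound 2 to compound 3 cannot be read for the same reason.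

Compound 4 `CC/C(=N\NC(=O)c1cccnc1)c1ccccc1O` is the next entry. The change from compound 3 is pyridin-3-yl in place of pyridazin-4-yl on a carbonyl carbon. For the measured compounds named here, no measured step in this assay bears directly on this exchange, since compound 2 and compound 3 both sit at limits. Going by the values given here, the only fixed number carrying a pyridin-3-yl on the carbonyl carbon is that of compound 1, 6800 nM, which differs from compound 4 in the ethyl against methyl. On that basis compound 4 is expected at 20000 nM in this assay, within 5000 nM to 100000 nM. The step of an at least 10-fold lower number from compound 3 to compound 4 (1.00 log units; beyond the scatter) is thus expected to move downward from the limit, though a further limit remains possible.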

Compound 4, half-maximal inhibitory concentration: 7100 nM
For compound 4 the middle estimate is 2.8-fold (0.45 log units) above the measured one, within the range that was stated.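

The methyl-to-ethyl question can now be read in this assay, where the exchange gives a 1.0-fold higher number from compound 1 to compound 4 (0.02 log units; within the scatter), so the added methyl on the saturated chain carbon leaves no readable mark on the result. With the ethyl held constant, the ring on the carbonyl carbon alone separates the compounds: pyridin-3-yl, with 1 hetero atom, gives an at least 28-fold lower number from compound 3 to compound 4 (1.44 log units; beyond the scatter) against pyridazin-4-yl and an at least 14-fold lower number from compound 2 to compound 4 (1.14 log units; beyond the scatter) against pyrazin-2-yl, and both sizes are minimums since each starts from a limit of the assay. Among compounds 2, 3 and 4, the large difference therefore follows the exchange of a ring with 2 hetero atoms for one with 1 hetero atom, but nothing at hand gives a reason for these steps.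

Compounds 2 and 3 both stand at limits, so the step between them cannot be read and the two rings cannot be ordered. As far as these compounds go, it remains open whether a phenyl or a pyridin-2-yl on the carbonyl carbon would stay near compound 4, and whether a propyl chain in place of the ethyl would leave the value unchanged as the ethyl did.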